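Estimating stability for a 2-hydroxycycloheptyl compound without a baseline

The source may report more compounds than this note shows. Statements on the series, on what has been measured and on what is new or still open speak of the compounds shown alone.

Three measured or attempted compounds share one core: compound 1 `Cc1c(Cl)cccc1Oc1cccn2c(C3CCOCC3)nnc12`, compound 2 `CC(=O)N1CCC(c2nnc3c(Oc4cccc(Cl)c4C)cccn23)CC1` and compound 3 `Cc1c(Cl)cccc1Oc1cccn2c(C34CCC(N)(CC3)CC4)nnc12`. In an ADME assay on microsomes from liver (Homo sapiens) for metabolic stability, with a stated time of 10 min (on this read-out higher numbers stand for a more stable compound and lower numbers for a less stable compound), compound 1 gives 100% and compound 2 gives 87%. For compound 3, the result in this assay reads "not determined" (no result reported), so it offers no number to start from.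

Compound 4 `Cc1c(Cl)cccc1Oc1cccn2c(C3CCCCCC3O)nnc12` differs from compound 3 at a single place: a group of 8 heavy atoms (7 carbon, 1 oxygen; one seven-membered non-aromatic ring of carbon only) in place of a group of 9 heavy atoms (8 carbon, 1 nitrogen; 2 six-membered non-aromatic rings of carbon only), on an aromatic carbon. The group that enters is 2-hydroxycycloheptyl.

For the measured compounds named here, only one measured step bears on this change: a number 13 percentage points lower from compound 1 to compound 2 (beyond the scatter). It also replaces one group with another on an aromatic carbon, and it is modest but beyond the scatter. Still, it is a different swap and a single example, so it suggests only a rough size. Going by the values given here, without a number for compound 3, no step from it can be sized or given a direction, and the expectation must lean on the two measured neighbours. Given that compound 2 reads 87%, compound 4 is expected to fall in the same region, perhaps a little lower. The estimate for compound 4 is 80%, with an expected range of 55% to 98%.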

Compound 4, percent of the compound remaining: 81%
Estimate against measurement, compound 4: 1 percentage points below; the range from low to high includes it.
By their numbers in this assay, from the lowest: compounds 4 and 2 (each within the scatter of the next); then compound 1.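

In this assay, the aromatic carbon between two ring nitrogen atoms now carries a third kind of group, 2-hydroxycycloheptyl, and the comparison with 1-acetylpiperidin-4-yl reads a number 6 percentage points lower from compound 2 to compound 4 (within the scatter), so these two groups cannot be told apart on this read-out. Against oxan-4-yl, the same change reads a number 19 percentage points lower from compound 1 to compound 4 (beyond the scatter) and lies beyond the usual scatter, as the step to 1-acetylpiperidin-4-yl does, which leaves compound 1 with the highest number of the three measured compounds. Steps from compound 3 cannot be read, as it has no number, and nothing available accounts for the differences among the other compounds.

The compounds shown do not separate the seven-membered ring from its hydroxyl group, so the share of each in the result for compound 4 stays open. On these data alone, it is also open whether a plain cycloheptyl with no oxygen, or a cycloheptyl carrying an amine in place of the hydroxyl group, would read closer to compound 1 or to compound 4.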